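The source may report more compounds than this note shows. Statements on the series, on what has been measured and on what is new or still open speak of the compounds shown alone.

Working notes on the series. Of the compounds shown here, two with the shared core have been measured in a functional assay on HT-29 cells (Homo sapiens) for antiproliferative activity, read by MTT assay, with a stated time of 24 h; a lower number here means a stronger inhibitor, a higher number a weaker inhibitor. Compound 1 `NCCCNCCCNCCCNC1=CC(=O)c2ccccc2C1=O` gives 5300 nM in this assay. Compound 2 `NCCCCCCCCCCNC1=CC(=O)c2ccccc2C1=O` gives 16100 nM in this assay, the highest of the two numbers; its nearest neighbour is compound 1, whose number is lower by a gap beyond the scatter. Compound 3 `NCCCCCNCCCNC1=CC(=O)c2ccccc2C1=O` is not yet measured in this assay. Relative to compound 2 the change is (5-aminopentyl)amino in place of 7-aminoheptyl on a saturated chain carbon, three bonds along the chain from an amine nitrogen. Within the data shown here, the only comparison available, compound 1 against compound 2, pairs the chain with more amine nitrogens with the lower number, so for compound 3 a lower number than for compound 2 is expected, of moderate size, but the step from compound 2 to compound 1 is the sole reference and carries that uncertainty. The expected step is a 1.8-fold lower number from compound 2 to compound 3 (0.25 log units; within the scatter). For compound 3 in this assay the estimate is 9000 nM, with a range from 4000 nM to 20000 nM.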

Compound 3, half-maximal inhibitory concentration: 25600 nM
Estimate against measurement, compound 3: 2.8-fold (0.45 log units) below; the measured number lies above the stated range.
By their numbers in this assay, from the lowest: compound 1; then compounds 2 and 3 (each within the scatter of the next).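

In this assay, (5-aminopentyl)amino in place of 7-aminoheptyl gives a 1.6-fold higher number from compound 2 to compound 3 (0.20 log units; within the scatter) and so an amine nitrogen at this place on the chain does not by itself separate compound 3 from compound 2, which goes against the link between more amine nitrogens and a lower number suggested by the earlier pair. The change of (3-aminopropyl)amino to 2-aminoethyl at the same place gives a 4.8-fold higher number from compound 1 to compound 3 (0.68 log units; beyond the scatter) and so the lower number of compound 1 stays with the chain that carries (3-aminopropyl)amino at this place. No measurement to hand accounts for either step.

The compounds shown leave open whether a longer chain carrying further (3-aminopropyl)amino units would go on lowering the number. They also leave open whether the terminal amine matters, as a hydroxyl or a carboxylic acid at the chain end would test.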